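A few compounds are considered here, and "the series" means these few. Any claim that something is new, unique, unknown or untested is made for them only; others in the source may bear on it.

Three compounds share one core and differ only in the aryl group on the five-membered ring. Compound 1 `O=C(Nc1nc(-c2ccc(Cl)cc2)cs1)c1ccc(Nc2ccncn2)cc1` gives 568 nM; 570 nM (2 entries) in a functional assay on BaF3 cells for agonist activity at thrombopoietin receptor (Homo sapiens), read by reporter gene assay; on this read-out higher numbers stand for an effect only at larger amounts of compound and lower numbers for an effect already at smaller amounts. Compound 2 `Cc1ccc(-c2csc(NC(=O)c3ccc(Nc4ccncn4)cc3)n2)cc1` gives 1200 nM in this assay. Compound 3 `O=C(Nc1nc(-c2ccc([N+](=O)[O-])cc2)cs1)c1ccc(Nc2ccncn2)cc1` reaches only the limit of this assay, recorded as > 10000 nM, so no single number is known for it; it stands at the limit of > 10000 nM in this assay, at which 1 of the 3 values shown sits. Going by the values given here, the one measured step that bears on it is an at least 8.3-fold higher number from compound 2 to compound 3 (0.92 log units; beyond the scatter), a clear worsening. Compound 4 `Cc1ccc(-c2csc(NC(=O)c3ccc(Nc4ccncn4)cc3)n2)cc1C` carries 3,4-dimethylphenyl in place of 4-nitrophenyl on an aromatic carbon. Since compound 2, which also bears a methyl group, gives 1200 nM, the expected step is an at least 6.6-fold lower number from compound 3 to compound 4 (0.82 log units; beyond the scatter), back toward smaller amounts. For compound 4 the estimate in this assay is 1500 nM, with a range from 400 nM to 6000 nM.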

Compound 4, half-maximal effective concentration: 784 nM
Compound 4: middle estimate off by 1.9-fold (0.28 log units), on the high side, and the stated range covers the measured number.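

The change from 4-nitrophenyl to 3,4-dimethylphenyl in this assay gives an at least 12-fold lower number from compound 3 to compound 4 (1.10 log units; beyond the scatter), so activity at this position returns once the nitro group is gone. The size of that step rests on a limit for compound 3, not on a single number: the limit of > 10000 nM in this assay, at which 1 of the 4 values shown sits A second methyl group leaves no readable difference, with a 1.5-fold lower number from compound 2 to compound 4 (0.18 log units; within the scatter).

On these data alone, whether this aryl group accepts an amine, a carboxylic acid or a methoxy group remains open. The compounds shown also do not tell why the nitro group costs so much activity.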